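From Amino to Diethylamino on the Shared Core

The source may report more compounds than this note shows. Statements on the series, on what has been measured and on what is new or still open speak of the compounds shown alone.

Measured in a functional assay on HEK293 cells for activation of melanin-concentrating hormone receptor 1 (Rattus norvegicus), read by inositol phosphate accumulation; on this read-out lower numbers stand for an effect already at smaller amounts and higher numbers for an effect only at larger amounts of compound:
compound 1 `O=C(CCc1ccc(C(F)(F)F)cc1)Nc1ccc2nc(N3CCC3)ccc2c1` gives 56 nM;
compound 2 `CN(C)c1ccc2cc(NC(=O)CCc3ccc(C(F)(F)F)cc3)ccc2n1` gives 110 nM;
compound 3 `Nc1ccc2cc(NC(=O)CCc3ccc(C(F)(F)F)cc3)ccc2n1` gives 720 nM.

Among these three numbers in this assay, compound 3 stands highest, with compound 2 nearest to it and compound 1 furthest away. Compound 4 `CCN(CC)c1ccc2cc(NC(=O)CCc3ccc(C(F)(F)F)cc3)ccc2n1` differs from compound 3 by diethylamino in place of amino on an aromatic carbon. Among the compounds with values here, two measured steps bear on this change: a 6.5-fold higher number from compound 2 to compound 3 (0.82 log units; beyond the scatter) and a 13-fold higher number from compound 1 to compound 3 (1.11 log units; beyond the scatter), both beyond the scatter, while a 2.0-fold higher number from compound 1 to compound 2 (0.29 log units; within the scatter) stays within it. The step to compound 4 runs in the opposite direction from those two, so a lower number beyond the scatter is expected. Compound 4 is therefore expected to give an estimated 110 nM, with an expected range from 40 nM to 300 nM, and this estimate means an expected 6.5-fold lower number from compound 3 to compound 4 (0.82 log units; beyond the scatter).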

Compound 4, half-maximal effective concentration: 830 nM
For compound 4 the middle estimate is 7.5-fold (0.88 log units) below the measured one; measured number above the stated range.
By their numbers in this assay, from the lowest: compounds 1 and 2 (each within the scatter of the next); then compounds 3 and 4 (each within the scatter of the next).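

In this assay, diethylamino in place of amino on the carbon next to the ring nitrogen gives a 1.2-fold higher number from compound 3 to compound 4 (0.06 log units; within the scatter) and leaves the number unmoved, while diethylamino in place of dimethylamino gives a 7.5-fold higher number from compound 2 to compound 4 (0.88 log units; beyond the scatter) and in place of azetidin-1-yl gives a 15-fold higher number from compound 1 to compound 4 (1.17 log units; beyond the scatter) in this same comparison. Two carbon chains on this nitrogen are therefore not enough to keep the lower numbers of compound 1 and compound 2. Nothing measured here explains this outcome.

Open, as far as these compounds go, is how methylamino, pyrrolidin-1-yl or piperidin-1-yl would stand at this place on the shared core.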